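The source may report more compounds than this note shows. Statements on the series, on what has been measured and on what is new or still open speak of the compounds shown alone.

Compound 1 `O=S1(=O)c2ccccc2CN1c1cc(F)cc(OCc2ccccc2)c1` and compound 2 `N#Cc1ccc(Oc2cc(F)cc(N3Cc4ccccc4S3(=O)=O)c2)cc1` share one core and differ only in the group set on the oxygen on the aromatic ring. In a functional assay on Flp-In T-REx293 cells for antagonist activity at Free fatty acid receptor 1 (Homo sapiens), read by calcium flux (a higher number here means a weaker inhibitor, a lower number a stronger inhibitor), compound 1 gives 2450 nM, and compound 2 gives 617 nM; the step between them is a 4.0-fold lower number from compound 1 to compound 2 (0.60 log units; beyond the scatter). Among the measured compounds shown here, compound 2 thus stands at the lower of the two numbers measured so far, with compound 1 the only other point. Compound 3 `O=S1(=O)c2ccccc2CN1c1cc(F)cc(Oc2ccccn2)c1` is not yet measured; its change from compound 2 is pyridin-2-yl in place of 4-cyanophenyl on an oxygen on an aromatic ring. For the measured compounds named here, that single measured step bears on it only in part: the entering group of compound 3, like that of compound 2, is an aromatic ring placed directly on the oxygen, but the nitrile is lost, and no measured pair shows what its removal does. A step of a 1.9-fold higher number from compound 2 to compound 3 (0.29 log units; within the scatter) in this assay is therefore expected, most likely towards a weaker inhibitor, with little certainty. For compound 3 a value of 1200 nM in this assay is estimated, in the range 400 nM to 4000 nM.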

Compound 3, half-maximal inhibitory concentration: > 100000 nM
Compound 3 gave a limit, no number; the forecaster's own chance of this, stated with the estimate: 10%; middle value at least 83-fold (1.92 log units) away from the limit.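

In this assay compound 3 gives a limit of the assay and not a number: the limit of > 100000 nM in this assay, at which 1 of the 3 values shown sits. Against the 4-cyanophenyl group, the change gives an at least 160-fold higher number from compound 2 to compound 3 (2.20 log units; beyond the scatter), and against the benzyl group it gives an at least 40-fold higher number from compound 1 to compound 3 (1.61 log units; beyond the scatter). An aromatic ring placed directly on the oxygen therefore does not by itself carry the activity of compound 2, and a position that had shown only a modest step between benzyl and 4-cyanophenyl proves highly sensitive to the group it carries.

This change both removes the nitrile and places a nitrogen in the ring, so the two effects remain unseparated; a plain phenyl or a cyanopyridinyl group on the oxygen would tell them apart. Also open, as far as these compounds go, is whether a carboxylic acid or an amine on that ring would be accepted at this position.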